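Removing the N-methyl from the anilino series: stability notes

The compounds below may be only part of what the source reports. "The series", "measured", "known", "first", "only" and "open" are said of these compounds alone.

Two compounds on the shared core have been run in an ADME assay on microsomes from liver (Homo sapiens) for metabolic stability, read by LC-MS, using NADPH, with stated times of 5 min and 30 min, tested at 1 uM (a higher number here means faster removal of the compound, a lower number slower removal), so far. Compound 1 `CN(C)Cc1ccc2c(c1)CN(c1cnc(NCc3c(F)ccc4c3CCO4)n3cnnc13)C2=O` carries the larger fused substituent on the core and gives 19 mL.min-1.g-1 in this assay. Going by the values given here, compound 2 `CN(c1ccccc1)c1cnc(NCc2c(F)ccc3c2CCO3)n2cnnc12` gives 55 mL.min-1.g-1 in this assay, the higher of the two numbers; the gap between compound 2 and compound 1 is beyond the usual scatter of repeat runs, so compound 2 is removed faster than compound 1 in this assay, and it is the only compound with a methyl(phenyl)amino group among the measured pair.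

Compound 3 `Fc1ccc2c(c1CNc1ncc(Nc3ccccc3)c3nncn13)CCO2` has not yet been measured in this assay. It differs from compound 2 in one place, (hydrogen in place of methyl on a nitrogen on an aromatic ring), so that the methyl(phenyl)amino group becomes an anilino group. Among the compounds with values here, no measured pair shows this change, and nothing among the two measured compounds fixes its direction or size. The step from compound 2 to compound 3 is expected to be a modest decrease in clearance, a 1.6-fold lower number from compound 2 to compound 3 (0.20 log units; within the scatter), though a result within the scatter would not be surprising. For compound 3 the estimate in this assay is 35 mL.min-1.g-1, with a range from 15 mL.min-1.g-1 to 80 mL.min-1.g-1.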

Compound 3, intrinsic clearance in microsomes: 20 mL.min-1.g-1
Estimate against measurement, compound 3: 1.8-fold (0.24 log units) above; the range from low to high includes it.
By their numbers in this assay, from the lowest: compounds 1 and 3 (each within the scatter of the next); then compound 2.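

In this assay, going by these compounds alone, hydrogen in place of methyl on a nitrogen on an aromatic ring gives a 2.8-fold lower number from compound 2 to compound 3 (0.44 log units; beyond the scatter) and so provides the first single-change comparison on the shared core, with both a measured direction and a measured size. The two compounds differ only in that one carbon, as the methyl(phenyl)amino group becomes an anilino group, so within this pair the higher number of compound 2 goes with the presence of the methyl. Nothing among the data shown accounts for the size or direction of this step, and the pair records only what happens to the number, not the reason for it.

From the compounds shown here alone, whether an ethyl or a longer chain on this nitrogen would move the number further in the same direction, or reverse it, remains open, as does the effect of a fluoro or methoxy group on the phenyl ring of the anilino group. Within the data shown here, with only this single pair, it also remains open whether the same exchange of methyl for hydrogen would give a similar step with other groups elsewhere on the shared core.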